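This account rests on a few compounds, and the source may have more. Where it says the series, first, only, none or still open, it means among the compounds named here.

Measured so far:
compound 1 `CCOc1ccc(/C=C2\CN(CC(=O)O)c3c(C)cccc3C2=O)cc1` gives 42.4%
compound 2 `COc1ccc(OC)c(/C=C2\CN(CC(=O)O)c3c(C)cccc3C2=O)c1` gives 5.44%
compound 3 `Cc1ccc2c(c1)C(=O)/C(=C/c1ccc(Cl)cc1)CN2CC(=O)O` gives 20.7%

All three numbers come from an assay on HL-60 cells for inhibition of glutathione S-transferase P (Homo sapiens), read by spectrophotometry, tested at 20 uM; a higher number here means more inhibition at the concentration tested (going by the name of the read-out), a lower number less inhibition. Compound 1 stands highest of the three; compound 3 lies below it, and the gap is beyond the scatter. Compound 2 lies furthest below compound 1, again beyond the scatter. Going by the values given here, with only three compounds and no pair differing in a single place, no step between measured compounds can be drawn, so the shared core carries no tested change of its own yet.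

Compound 4 `Cc1cccc2c1N(CC(=O)O)C/C(=C\c1ccccc1)C2=O` is the next compound to go into this assay. Relative to compound 1 the change is hydrogen in place of ethoxy on an aromatic carbon. Among the compounds with values here, nothing measured so far isolates the ethoxy group, so the expected direction rests only on compound 1 having the highest number in the set: a drop beyond the scatter is expected, toward the numbers of compound 3 and compound 2. The expected step is a number 20.4 percentage points lower from compound 1 to compound 4 (beyond the scatter). Compound 4 is estimated at 22%, expected within 5% to 40%.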

Compound 4, a percentage reported as inhibition, at one concentration (the size of the read-out at that concentration, not a potency): 27.9%
Beside the measured number, compound 4's estimate is 5.9 percentage points below it, within the range that was stated.
By their numbers in this assay, from the lowest: compound 2; then compounds 3 and 4 (each within the scatter of the next); then compound 1.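

In this assay, the series now has its first comparison in a single place, hydrogen in place of ethoxy on an aromatic carbon para to a large group, and it gives a number 14.5 percentage points lower from compound 1 to compound 4 (beyond the scatter) as a modest step beyond the scatter. Ethoxy at this position therefore counts for something in this assay, but it is not required: compound 4, which carries only hydrogen there, still gives 27.9% in this assay. No measurement on hand gives a reason for this step.

On these data alone, it remains open whether the step follows the oxygen of ethoxy or its two carbons, which a methoxy or hydroxyl group at the same carbon could separate. As far as these compounds go, it also remains open whether a longer chain such as butoxy, or an amine, at this place would reach or pass the number of compound 1.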